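The source may hold more compounds than are shown below. What is called first, only, known or untested is meant among the compounds shown, and "the series" means these compounds.

Of the compounds shown here, two have so far been tested in a functional assay on PC-12 cells (Rattus norvegicus) for cytotoxicity, read by MTT assay, with stated times of 3 h and 2 h, tested at 5 uM; a lower number here means a weaker effect, a higher number a stronger effect of the compound at the concentration tested. Compound 1 `O=C(CCCCC1CCSS1)NCc1cn(CCCOc2ccc3ccc(=O)oc3c2)nn1` gives 39.2% in this assay. Compound 2 `O=C(CCCCC1CCSS1)NCc1cn(CCCCOc2ccc3ccc(=O)oc3c2)nn1` gives 52.8% in this assay, which is the higher of the two numbers; the gap to compound 1 lies beyond the usual scatter of such measurements, so compound 2 shows the clearer effect of the pair.

Compound 3 `O=C(CCCCC1CCSS1)NCc1cn(CCCCOc2ccc3cc(-c4ccc(Br)cc4)c(=O)oc3c2)nn1` has not yet been measured. Compared with compound 2, it carries 4-bromophenyl in place of hydrogen on an aromatic carbon. The new group sits two atoms from the ring oxygen of the shared core, ortho to a group of one heavy atom and para to a fused ring.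

Going by the values given here, since no pair of measured compounds differs in only one place, there is no measured step to lean on for this kind of change in this assay, and the size of the step from compound 2 to compound 3 is open. The expectation is that compound 3 will land near compound 2, with an estimated step of a number 2.2 percentage points higher from compound 2 to compound 3 (within the scatter), that is, no change beyond the scatter in either direction. For compound 3 the estimate in this assay is 55%, within a range from 35% to 75%.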

Compound 3, a percentage reported as activity, at one concentration (the size of the read-out at that concentration, not a potency): 40.5%
For compound 3 the middle estimate is 14.5 percentage points above the measured one, within the range that was stated.
By their numbers in this assay, from the lowest: compounds 1 and 3 (each within the scatter of the next); then compound 2.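

In this assay, placing 4-bromophenyl in place of hydrogen on this aromatic carbon, two atoms from the ring oxygen, gives a number 12.3 percentage points lower from compound 2 to compound 3 (beyond the scatter). Going by these compounds alone, this is the first measured step that changes one place only, and it shows that this position is not silent: a group attached here alters the read-out at the concentration tested. The step is modest and points downward, so this group, with its 7 heavy atoms and its aromatic ring, takes away part of the effect seen for compound 2 rather than adding to it, and no measurement at hand bears on why the number falls.

A plain phenyl or a methyl on the same carbon would help to show whether the step belongs to the bromine, to the ring or simply to having any group at this position. Going by these compounds, it also remains open whether 4-bromophenyl at this place would move the number in the same direction on the chain carried by compound 1.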